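The source may report more compounds than this note shows. Statements on the series, on what has been measured and on what is new or still open speak of the compounds shown alone.

Values in a functional assay on PC-3 cells (Homo sapiens) for antiproliferative activity, read by MTT assay, with a stated time of 72 h; on this read-out higher numbers stand for weaker inhibition and lower numbers for stronger inhibition:
- compound 1 `O=C(N/N=C/c1cccc(Br)c1)Nc1ccc(Oc2ccnc3[nH]ccc23)c(F)c1`: 4020 nM
- compound 2 `N#Cc1ccc(/C=N/NC(=O)Nc2ccc(Oc3ccnc4[nH]ccc34)c(F)c2)cc1`: 9030 nM

Of the two, compound 2 has the higher number, 9030 nM, and so the weaker inhibition. Compound 3 `O=C(N/N=C/c1ccc(Cl)c(Cl)c1)Nc1ccc(Oc2ccnc3[nH]ccc23)c(F)c1` has not yet been measured. It differs from compound 2 as follows: 3,4-dichlorophenyl in place of 4-cyanophenyl on a carbon with a double bond to nitrogen. Among the measured compounds shown here, only one measured step bears on this change: a 2.2-fold higher number from compound 1 to compound 2 (0.35 log units; beyond the scatter). That modest step put 4-cyanophenyl in place of 3-bromophenyl on a carbon with a double bond to nitrogen. Compound 3 gives up the 4-cyanophenyl for 3,4-dichlorophenyl, another aryl group carrying halogen, like the 3-bromophenyl of compound 1 at 4020 nM. One step is thin support, so only a modest move to a lower number is expected in this assay. The expected step is a 2.0-fold lower number from compound 2 to compound 3 (0.30 log units; within the scatter). For compound 3 the estimate is 4500 nM, with an expected range of 1600 nM to 11000 nM.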

Compound 3, half-maximal inhibitory concentration: 14100 nM
Compound 3: the middle estimate sits 3.1-fold (0.50 log units) below what was measured; the whole stated range lies below it.
By their numbers in this assay, from the lowest: compound 1; then compounds 2 and 3 (each within the scatter of the next).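

In this assay, the exchange of 4-cyanophenyl for 3,4-dichlorophenyl gives a 1.6-fold higher number from compound 2 to compound 3 (0.19 log units; within the scatter), so at this carbon with a double bond to nitrogen the two aryl groups cannot be told apart, even though one carries a nitrile and the other two chlorines. The change from 3-bromophenyl to 3,4-dichlorophenyl gives a 3.5-fold higher number from compound 1 to compound 3 (0.54 log units; beyond the scatter), which shows that a halogen on the aryl group does not by itself match compound 1, still the lowest number of the three. No measurement here explains why these aryl groups differ or fail to differ.

The compounds shown leave open how a single chlorine compares with the 3-bromophenyl group of compound 1. They also leave open whether a methoxy group or an amine on the aryl ring would move the number outside this narrow range.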